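The source may report more compounds than this note shows. Statements on the series, on what has been measured and on what is new or still open speak of the compounds shown alone.

Measured so far:
compound 1, `CCN1CC(NC(=O)[C@@H]2CCCN(S(=O)(=O)c3ccc(S(=O)(=O)N(CC)CC)cc3)C2)C1`: > 10000 nM
compound 2, `CC(C)c1noc(N2CCN(C(=O)[C@@H]3CCCN(S(=O)(=O)c4ccc(S(=O)(=O)C5CCC5)cc4)C3)CC2)n1`: 20 nM

In a functional assay on MIA PaCa-2 cells (Homo sapiens) for inhibition, read by MTT assay, with a stated time of 3 days (on this read-out lower numbers stand for stronger inhibition and higher numbers for weaker inhibition), compound 1 gives only a limit, > 10000 nM. For the measured compounds named here, compound 2 gives the only number in this assay, 20 nM. The other value shown is that of compound 1, (the limit of > 10000 nM in this assay, at which 1 of the 2 values shown sits). Compound 3, `CCNS(=O)(=O)c1ccc(S(=O)(=O)N2CCC[C@@H](C(=O)N3CCN(c4nc(C(C)C)no4)CC3)C2)cc1`, is yet to be measured. It differs from compound 2 as follows: ethylamino in place of cyclobutyl on a sulfonyl sulfur. Going by the values given here, no step between measured compounds covers this change, so the size of the step is uncertain; a small loss is expected, of a size close to the scatter, a 2.3-fold higher number from compound 2 to compound 3 (0.35 log units; beyond the scatter). Compound 3 is estimated at 45 nM, within 12 nM to 250 nM.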

Compound 3, half-maximal inhibitory concentration: 200 nM
Compound 3: middle estimate off by 4.4-fold (0.65 log units), on the low side; low and high end bracket the measured number.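

In this assay the group on a sulfonyl sulfur whose other neighbours are aromatic carbon matters: ethylamino in place of cyclobutyl gives a 10-fold higher number from compound 2 to compound 3 (1.00 log units; beyond the scatter). This is the only one-place comparison shown, and compound 3 keeps a measurable value of 200 nM, so an open chain with a hydrogen-bond donor at this place still leaves activity in this assay. No measurement shown gives a reason for the size of this step.

Open, on these data alone, is whether the loss follows the loss of the ring or the entry of nitrogen. A plain ethyl or a cyclobutylamino group on the same sulfur would separate the two.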